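Swapping dichlorophenyl for dimethoxyphenyl on the carbonyl

The compounds below may be only part of what the source reports. "The series", "measured", "known", "first", "only" and "open" are said of these compounds alone.

Measured compounds in a functional assay on HCC 2998 cells (Homo sapiens) for inhibition, read by sulforhodamine B assay, with a stated time of 48 h; a lower number here means a stronger inhibitor of growth, a higher number a weaker inhibitor of growth:
compound 1 `COc1cc(-c2cc(/C=C/C(=O)c3ccc(Cl)c(Cl)c3)[nH]n2)cc(OC)c1OC` gives 9560 nM
compound 2 `COc1ccc(-c2cc(/C=C/C(=O)c3cc(OC)c(OC)c(OC)c3)[nH]n2)cc1OC` gives 1900 nM
compound 3 `COc1ccc(-c2cc(/C=C/C(=O)c3ccc(N)cc3)[nH]n2)cc1` gives 1830 nM

Of the three compounds measured, compound 1 stands at the highest number, so it is the weakest inhibitor of growth in the set. Compound 2 and compound 3 lie at lower numbers, both far enough from compound 1 that the gaps are beyond the scatter of repeated measurements; the two of them sit close to each other, within that scatter.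

The step from compound 1 to compound 4 `COc1ccc(C(=O)/C=C/c2cc(-c3cc(OC)c(OC)c(OC)c3)n[nH]2)cc1OC` changes only the group on the carbonyl carbon whose other neighbour is a double-bonded chain carbon: 3,4-dimethoxyphenyl in place of 3,4-dichlorophenyl on a carbonyl carbon. The rest of the shared core is untouched. Among the measured compounds shown here, no pair of measured compounds differs in exactly one place, so there is no directly measured step to lean on. For the measured compounds named here, still, the only compounds in the set carrying methoxy-bearing rings on the carbonyl side, compound 2 with 1900 nM and compound 3 with 1830 nM, sit well below compound 1 with 9560 nM.

On that basis compound 4 is expected to move to a lower number than compound 1, a step of a 3.8-fold lower number from compound 1 to compound 4 (0.58 log units; beyond the scatter) that is estimated to lie beyond the scatter. The estimate for compound 4 is 2500 nM, with a range from 900 nM to 7000 nM.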

Compound 4, concentration for 50% growth inhibition: 2130 nM
Beside the measured number, compound 4's estimate is 1.2-fold (0.07 log units) above it; measured number inside the range.
By their numbers in this assay, from the lowest: compounds 3, 2 and 4 (each within the scatter of the next); then compound 1.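

With the rest of the shared core held fixed, 3,4-dimethoxyphenyl in place of 3,4-dichlorophenyl on a carbonyl carbon gives a 4.5-fold lower number from compound 1 to compound 4 (0.65 log units; beyond the scatter) in this assay. The earlier compounds shown here could offer only a hint here, as no two of them differed in one place, whereas this pair ties the lower number to this single change and shows that the number in this assay responds to the group at this position. The data shown offer no measurement that explains the size or direction of this step.

One pair cannot tell whether the lower number comes from gaining the two methoxy groups or from losing the two chlorine atoms, so a ring carrying a single methoxy group or a single chlorine atom at this position remains an open comparison. It also leaves open how a hydroxyl group or a fluorine atom on this ring would compare, and whether the same swap would give a step of similar size if the shared core carried a different group elsewhere.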